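The compounds below may be only part of what the source reports. "The series", "measured", "known", "first", "only" and "open" are said of these compounds alone.

Compound 1, `CNC1CC2CCC1(C)C2(C)C`, compound 2, `CNC1C2CCC(C2)C1(C)C`, and compound 3, `CNC1CC2CCC1C2`, were all characterised in a physicochemical assay for lipophilicity (a higher number here means a more lipophilic compound, a lower number a more polar compound), together with compound 4, `CNC1C2CCC(C2)C1C`, which has not yet been measured there. In this assay compound 1 gives 3.53, and compound 2 gives 3.01. Compound 3 was measured twice and gives 1.97; 1.97 (2 entries), so it carries no single number. Among the two single numbers compound 2 stands lowest; its nearest neighbour is compound 1, whose number lies higher by more than the usual scatter. The step from compound 2 to compound 4 is hydrogen in place of methyl on a saturated ring carbon, a hydrogen in place of a methyl on a saturated ring carbon. Compound 4 is expected to come out lower, with a step from compound 2 to compound 4 estimated at a number 0.46 log units lower from compound 2 to compound 4 (beyond the scatter). The estimate for compound 4 in this assay is 2.55, within a range of 2.2 to 2.9.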

Compound 4, partition coefficient: 2.49
Compound 4: the middle estimate sits 0.06 log units above what was measured; measured number inside the range.
By their numbers in this assay, from the lowest: compound 4; then compound 2; then compound 1.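

In this assay, hydrogen in place of methyl on this saturated ring carbon gives a number 0.52 log units lower from compound 2 to compound 4 (beyond the scatter). Going by these compounds alone, this is the first step between measured compounds that differ in one place, and it shows that a change of a single methyl at this position moves the number beyond the scatter. Nothing measured here explains the size or direction of this step.

From the compounds shown here alone, what an ethyl chain or a hydroxyl group on the same ring carbon would give remains open. So does whether the step would hold if an amide replaced the methylamino group.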